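Swapping cyano for benzyloxycarbonyl on compound 3

This account rests on a few compounds, and the source may have more. Where it says the series, first, only, none or still open, it means among the compounds named here.

Measured so far in an ADME assay on BJ cells (Homo sapiens) for cytotoxicity, with a stated time of 72 h; on this read-out lower numbers stand for an effect already at smaller amounts and higher numbers for an effect only at larger amounts of compound:
- compound 1 `C=C[C@@](C)(/C=C/c1ccc(OC)cc1)CCC=C(C)C`: > 36600 nM
- compound 2 `C=C[C@@](C)(/C=C/c1ccc(O)c(/C=C/C#N)c1)CCC=C(C)C`: > 36600 nM
- compound 3 `COc1ccc(/C=C/[C@@](C)(/C=C/c2ccc(O)c(/C=C/C#N)c2)CCC=C(C)C)cc1`: > 23700 nM

None of these entries is a true number, since each is a limit of the assay. Two compounds share one limit: the limit of > 36600 nM in this assay, at which 2 of the 3 values shown sit. Compound 3 stands alone at the other: the limit of > 23700 nM in this assay, at which 1 of the 3 values shown sits. So no effect has yet been measured as a number in this series, and compound 3 cannot be ranked against compound 1 or compound 2.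

Compound 4 `COc1ccc(/C=C/[C@@](C)(/C=C/c2ccc(O)c(/C=C/C(=O)OCc3ccccc3)c2)CCC=C(C)C)cc1` keeps the core of compound 3 and differs in one place: benzyloxycarbonyl in place of cyano on a double-bonded chain carbon bound to a double-bonded chain carbon. The 2-cyanoethenyl group thus becomes 2-(benzyloxycarbonyl)ethenyl.

Within the data shown here, the only measured step, a step that the two limits leave unreadable from compound 2 to compound 3, concerns a different part of the molecule and has no readable size, so it gives no guide to this change. With no size to carry over, no step beyond the scatter in this assay is expected, and no direction can be favoured. The expected change is an at least 1.1-fold lower number from compound 3 to compound 4 (0.07 log units; that floor lies within the scatter), an estimate that rests on the limit of compound 3 alone. Compound 4 is estimated at 20000 nM, with an expected range of 6000 nM to 40000 nM.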

Compound 4, half-maximal effective concentration: > 36600 nM
Compound 4 was reported as a limit; the forecaster's own chance of this, stated with the estimate: 75%; middle value at least 1.8-fold (0.26 log units) away from the limit.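

Among these compounds, compound 3 and compound 4 both stand as limits rather than true numbers in this assay, so the change from cyano to benzyloxycarbonyl gives no step that can be read. The compounds shown leave open what amount of any of them produces an effect on these cells, and whether this change alters that amount at all.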